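Trifluoromethyl for ethoxy on a norepinephrine transporter ligand

This account rests on a few compounds, and the source may have more. Where it says the series, first, only, none or still open, it means among the compounds named here.

Compound 1, `CCOc1ccccc1OC(c1cccc(I)c1)C1CNCCO1`, has been tested in an assay on membranes from brain for displacement of a labelled ligand from Norepinephrine transporter (Rattus norvegicus) (on this read-out higher numbers stand for weaker inhibition and lower numbers for stronger inhibition), where compound 1 gives 28.5 nM. This is the lower of the two numbers recorded so far. For the measured compounds named here, the only other measured compound, compound 2, `Cc1ccccc1OC(c1ccc(I)s1)C1CNCCO1`, gives 71.9 nM in this assay, a higher number than compound 1 and a gap beyond the usual scatter; the two differ in more than one place, so the pair shows only this difference in outcome, not the weight of any single change.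

Compound 3, `FC(F)(F)c1ccccc1OC(c1cccc(I)c1)C1CNCCO1`, is not yet measured. Relative to compound 1 it carries trifluoromethyl in place of ethoxy on an aromatic carbon, a trifluoromethyl in place of ethoxy on an aromatic carbon. Going by the values given here, no measured pair isolates this change, so the step must be guessed. The step from compound 1 to compound 3 in this assay is expected to be a modest weakening, a 3.0-fold higher number from compound 1 to compound 3 (0.47 log units; beyond the scatter), somewhat beyond the scatter but not large. Compound 3 is therefore estimated at 85 nM, within a range from 25 nM to 300 nM.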

Compound 3, inhibition constant: 101 nM
Estimate against measurement, compound 3: 1.2-fold (0.07 log units) below; measured number inside the range.
By their numbers in this assay, from the lowest: compound 1; then compounds 2 and 3 (each within the scatter of the next).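

For the compounds shown here, compounds 1 and 3 are the first pair here that differ in one place only, so the weight of a single change can now be read. In this assay, trifluoromethyl in place of ethoxy on the aromatic carbon ortho to a large group gives a 3.5-fold higher number from compound 1 to compound 3 (0.55 log units; beyond the scatter) and that counts as a modest step, so what sits at this position does affect the read-out, though the swap does not abolish binding to the transporter. Ethoxy brings an oxygen and a two-carbon chain while trifluoromethyl brings three fluorines on one carbon, and nothing available here separates these differences or shows which of them moves the number.

On these data alone, with only ethoxy and trifluoromethyl compared at this position, it remains open how a methoxy, a longer chain such as propoxy, a chlorine or an amine would compare with them. As far as these compounds go, it is also open whether the same swap would give a step of similar size on a core other than that of compound 1.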